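Pyridin-4-yl in place of pyridin-3-yl: working notes

The source may hold more compounds than are shown below. What is called first, only, known or untested is meant among the compounds shown, and "the series" means these compounds.

Values measured so far in an ADME assay on LLC-MK2 cells (Macaca mulatta) for cytotoxicity, read by spectrophotometry and crystal violet staining, with a stated time of 4 days (on this read-out lower numbers stand for higher toxicity in this test and higher numbers for lower toxicity in this test), are:
- compound 1 `CC(C)n1ncc2c(C(=O)Nc3ccccn3)cc(-c3ccccc3)nc21` gives 12500 nM
- compound 2 `CC(C)n1ncc2c(C(=O)Nc3ncccn3)cc(-c3cccs3)nc21` gives 75000 nM
- compound 3 `CC(C)n1ncc2c(C(=O)Nc3ccccc3F)cc(-c3cccnc3)nc21` gives 50000 nM

Compound 3 (50000 nM) lies within the scatter of compound 2 (75000 nM). Compound 1 (12500 nM) gives a lower number than compound 3, and that gap is beyond the scatter.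

The next compound to be read is compound 4 `CC(C)n1ncc2c(C(=O)Nc3ccccc3F)cc(-c3ccncc3)nc21`, which carries pyridin-4-yl in place of pyridin-3-yl on an aromatic carbon of the shared core (pyridin-4-yl in place of pyridin-3-yl on an aromatic carbon). Going by the values given here, no two measured compounds differ in one place only, so no measured step shows the size of such a swap in this assay and the expectation is a weak one.

No shift beyond the scatter is expected in either direction, so the expectation stays close to compound 3 (50000 nM). The step of a 1.1-fold lower number from compound 3 to compound 4 (0.05 log units; within the scatter) is expected to lie within the scatter. For compound 4 the estimated value is 45000 nM (expected range 18000 nM to 100000 nM).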

Compound 4, half-maximal cytotoxic concentration: 45000 nM
The estimate for compound 4 equals the measured number at the digits printed; measured number inside the range.
By their numbers in this assay, from the lowest: compound 1; then compounds 4, 3 and 2 (each within the scatter of the next).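

Going by these compounds alone, for the first time a single-place step can be read in this assay: pyridin-4-yl in place of pyridin-3-yl on an aromatic carbon of the shared core gives a 1.1-fold lower number from compound 3 to compound 4 (0.05 log units; within the scatter). With the rest of the molecule held constant, where the nitrogen sits in this pyridine ring therefore makes no difference that this read-out can resolve, and compound 3 and compound 4 cannot be told apart. No accompanying measurement bears on this result.

From the compounds shown here alone, it remains open whether a group of a different kind at this carbon, such as a morpholine, a primary amine or a carboxylic acid, would shift the number beyond the scatter. Also open, going by these compounds, is whether the same pyridine swap stays as small alongside the amide groups of compound 1 and compound 2.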